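The source may report more compounds than this note shows. Statements on the series, on what has been measured and on what is new or still open speak of the compounds shown alone.

Compound 1 `N#Cc1ccc(Oc2cnccc2SCCCCCC(=O)O)c2ccccc12` is examined in an assay on HEK293 cells for inhibition of solute carrier family 22 member 12 (Homo sapiens), read by scintillation counting, with stated times of 30 min and 15 min (a lower number here means a stronger inhibitor, a higher number a weaker inhibitor), where compound 1 gives 4740 nM. Among the three measured compounds it holds the second highest number, yet its companions lie close: compound 2 `CN(c1cnccc1SC(C)(C)C(=O)O)c1ccc(C#N)c2ccccc12` gives 5360 nM and compound 3 `CN(c1cnccc1SCCCCCC(=O)O)c1ccc(C#N)c2ccccc12` gives 3760 nM, both within the scatter of compound 1, so no order among the three can be claimed. Within the data shown here, the one single-point step measured so far, a 1.4-fold lower number from compound 2 to compound 3 (0.15 log units; within the scatter), exchanges one acid-bearing chain on the sulfur for another and leaves the number essentially where it was. Compound 4 `N#Cc1ccc(Oc2cnccc2SCC(=O)O)c2ccccc12` differs from compound 1 by carboxy in place of 4-carboxybutyl on a saturated chain carbon bound to a sulfur, again an exchange of the acid-bearing chain on the sulfur, now a shortening. On the evidence of compound 2 and compound 3, whose chain exchange moved the number only a 1.4-fold lower number from compound 2 to compound 3 (0.15 log units; within the scatter), the step of a 1.3-fold higher number from compound 1 to compound 4 (0.10 log units; within the scatter) is expected to stay within the scatter. Compound 4 is therefore estimated to give 6000 nM in this assay, with a likely range from 2500 nM to 15000 nM.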

Compound 4, half-maximal inhibitory concentration: 6970 nM
Compound 4: middle estimate off by 1.2-fold (0.07 log units), on the low side; the measured number falls inside the stated range.
By their numbers in this assay, from the lowest: compounds 3, 1, 2 and 4 (each within the scatter of the next).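

In this assay, shortening the acid-bearing chain on the sulfur from 5-carboxypentyl to carboxymethyl gives a 1.5-fold higher number from compound 1 to compound 4 (0.17 log units; within the scatter), so in the core of compound 1 this large loss of chain length leaves the number inside the scatter. The earlier step on this position exchanged a branched chain for a straight one on a different core, whereas this one changes the length of a straight chain alone, and it too shows no measurable effect. Nothing available explains this tolerance of the shorter chain. Every compound shown keeps a carboxylic acid at the end of the chain on the sulfur, so what an amide or an amine in its place would give remains open. Also open, on these data alone, is whether a chain longer than 5-carboxypentyl would stay within the scatter.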